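Fluorophenyl to methylphenyl on the hydrazone series

This account rests on a few compounds, and the source may have more. Where it says the series, first, only, none or still open, it means among the compounds named here.

Compound 1 `C/C(=N\Nc1nc(-c2ccc(F)cc2)cs1)c1sc(C)nc1C` — > 100 ug/mL
Compound 2 `C/C(=N\Nc1nc(-c2ccc(F)cc2)cs1)c1sc(-c2ccccc2)nc1C` — > 100 ug/mL

In a toxicity assay on THP-1 cells (Homo sapiens) for cytotoxicity, read by MTT assay (on this read-out higher numbers stand for weaker inhibition of growth and lower numbers for stronger inhibition of growth), compound 1 gives > 100 ug/mL, which is a limit of the assay and not a number. In the same read-out compound 2 gives > 100 ug/mL, again a limit. Within the data shown here, the one measured change, phenyl in place of methyl on an aromatic carbon, is therefore a step that the two limits leave unreadable from compound 1 to compound 2: both values sit at the limit of > 100 ug/mL in this assay, at which 2 of the 2 values shown sit, so nothing can be read from it about size or direction. Compound 2 thus stands at the ceiling of what this assay reports, with no numbered value beneath it.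

Compound 3 `C/C(=N\Nc1nc(-c2ccc(C)cc2)cs1)c1sc(-c2ccccc2)nc1C` differs from compound 2 by methyl in place of fluoro on an aromatic carbon. Among the measured compounds shown here, no measured step touches this part of the shared core; the only step known, from compound 1 to compound 2, concerns a different place and is itself unreadable. There is thus no ground to expect compound 3 to leave the limit. The expectation for a step that the limit leaves unreadable from compound 2 to compound 3 is a step of no readable size. Compound 3 is expected to give about 120 ug/mL, within 60 ug/mL to 300 ug/mL, most likely again reported only as a limit.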

Compound 3, concentration for 50% growth inhibition: > 100 ug/mL
Compound 3: only a limit was reported; the forecaster's own chance of this, stated with the estimate: 85%; the middle value lies beyond the limit too.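

In this assay compound 3 gives > 100 ug/mL as a limit of the assay and not a number. No step can be read between compound 2 and compound 3, and the swap of 4-fluorophenyl for 4-methylphenyl stays unsized: the limit of > 100 ug/mL in this assay, at which 3 of the 3 values shown sit.

The compounds shown leave open whether any change on the shared core gives a numbered value in this assay at all.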